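Methyl in Place of Phenyl: an Expected Shift in Potency

The source may hold more compounds than are shown below. What is called first, only, known or untested is meant among the compounds shown, and "the series" means these compounds.

Of the compounds shown here, three sharing a common core have been measured in an assay on mitochondria for inhibition of Amine oxidase [flavin-containing] B (Rattus norvegicus); a lower number here means a stronger inhibitor, a higher number a weaker inhibitor. Compound 1 `NC(=O)[C@@H](NCc1ccc(OCc2cccc(Cl)c2)cc1)c1ccccc1` gives 10100 nM, compound 2 `NC(=O)[C@@H](NCc1ccc(OCc2ccccc2)cc1)c1ccccc1` gives 73800 nM, and compound 3 `NC(=O)[C@@H](CO)NCc1ccc(OCc2cccc(Cl)c2)cc1` gives 110 nM. Compound 2 stands highest of the three numbers, as the step of a 7.3-fold higher number from compound 1 to compound 2 (0.86 log units; beyond the scatter) shows, and compound 3 sits far lower still. The next compound, compound 4 `C[C@H](NCc1ccc(OCc2ccccc2)cc1)C(N)=O`, differs from compound 2 by methyl in place of phenyl on a saturated chain carbon bound to an amine nitrogen and a carbonyl carbon. Going by the values given here, no measured step covers this exact exchange. Among the compounds with values here, the only indication comes from compounds 1 and 3, which carry different groups on the saturated chain carbon bound to an amine nitrogen and a carbonyl carbon, and whose two values lie far apart, compound 3 holding the lower number. The direction compound 4 will take is thus uncertain, though a move in this assay beyond the scatter appears plausible. A moderately lower number is expected, amounting to a step of a 6.2-fold lower number from compound 2 to compound 4 (0.79 log units; beyond the scatter). Compound 4 is estimated at 12000 nM, within a range from 2500 nM to 60000 nM.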

Compound 4, half-maximal inhibitory concentration: 260 nM
For compound 4 the middle estimate is 46-fold (1.66 log units) above the measured one; measured number below the stated range.
By their numbers in this assay, from the lowest: compound 3; then compound 4; then compound 1; then compound 2.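

In this assay, methyl in place of phenyl on a saturated chain carbon bound to an amine nitrogen and a carbonyl carbon gives a 280-fold lower number from compound 2 to compound 4 (2.45 log units; beyond the scatter), so a single exchange at this position moves the number far more than the modest 7.3-fold higher number from compound 1 to compound 2 (0.86 log units; beyond the scatter). The earlier gap between compound 1 at 10100 nM and compound 3 at 110 nM involved a different group and carried chloro, whereas this step shows that phenyl at this position also goes with a high number in a compound without chloro. Nothing available explains the size of this step.

The compounds shown leave open whether ethyl, isopropyl or a longer chain at this position would keep a number as low as that of compound 4. They also leave open how chloro on an aromatic carbon would act in compound 4.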